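Extending the chain end of compound 2 with an ester

The compounds below may be only part of what the source reports. "The series", "measured", "known", "first", "only" and "open" are said of these compounds alone.

In an assay on HEK293 cells for displacement of a labelled ligand from prostaglandin D2 receptor 2 (Homo sapiens) (on this read-out lower numbers stand for stronger inhibition and higher numbers for weaker inhibition), compound 1 `O=C(O)Cn1c(SCCCOc2ccccc2)nc2ccccc21` gives 786 nM. Among the compounds with values here, compound 2 `CCCCCSc1nc2ccccc2n1CC(=O)O` gives 1240 nM, a number that sits within the scatter of compound 1, since the only measured step, a 1.6-fold higher number from compound 1 to compound 2 (0.20 log units; within the scatter), stays inside the usual spread. Compound 3 `CCOC(=O)CCCCSc1nc2ccccc2n1CC(=O)O` differs from compound 2 by ethoxycarbonyl in place of methyl on a saturated chain carbon, four bonds along the chain from a sulfur. The earlier step, a change at the chain end, is the one that bears on this change, and it was small. A step of a 1.0-fold lower number from compound 2 to compound 3 (0.01 log units; within the scatter) is therefore expected, nothing beyond the scatter. Compound 3 is estimated to give 1200 nM, within a range from 400 nM to 3600 nM.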

Compound 3, half-maximal inhibitory concentration: 2360 nM
Beside the measured number, compound 3's estimate is 2.0-fold (0.29 log units) below it, and the stated range covers the measured number.
By their numbers in this assay, from the lowest: compounds 1, 2 and 3 (each within the scatter of the next, the first and the last beyond it).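

In this assay, a 1.9-fold higher number from compound 2 to compound 3 (0.28 log units; within the scatter) stays inside the usual spread, so ethoxycarbonyl, with five heavy atoms against the single one of methyl, does not clearly separate from methyl at this place. Set against the phenoxy chain end, the same ester gives the first step here to pass the scatter, with a 3.0-fold higher number from compound 1 to compound 3 (0.48 log units; beyond the scatter) being a modest one. No measurement shown here explains either step. As far as these compounds go, how a carboxylic acid or an amide would read in place of the ethoxycarbonyl remains open, as does the effect of a shorter or longer chain carrying the ester.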